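Straightening the branched chain of compound 3

The source may hold more compounds than are shown below. What is called first, only, known or untested is meant among the compounds shown, and "the series" means these compounds.

In an ADME assay on A2780 cells (Homo sapiens) for antiproliferative activity, read by resazurin assay, with a stated time of 2 days (a lower number here means a stronger inhibitor, a higher number a weaker inhibitor), compound 1 (`CC(C)CCCCCc1cc(=O)c2ccccc2[nH]1`) gives 34000 nM, compound 2 (`CCCC(C)CCCc1cc(=O)c2ccccc2[nH]1`) gives 29000 nM and compound 3 (`CCC(C)CCCCc1cc(=O)c2ccccc2[nH]1`) gives 8700 nM. Compound 3 holds the lowest number of the three, and its steps to both others lie beyond the scatter.

Compound 4 (`CCCCCCCCc1cc(=O)c2ccccc2[nH]1`) has the same atoms as compound 3, joined differently: butyl in place of sec-butyl on a saturated chain carbon, four bonds along the chain from an aromatic carbon.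

The nearest measured change is at the same place, sec-butyl in place of isobutyl, a modest step of a 3.9-fold lower number from compound 1 to compound 3 (0.59 log units; beyond the scatter). Also modest is the step of a 3.3-fold lower number from compound 2 to compound 3 (0.52 log units; beyond the scatter), with 2-methylbutyl in place of 1-methylbutyl. The step of a 1.2-fold lower number from compound 1 to compound 2 (0.07 log units; within the scatter) stays within the scatter. For the measured compounds named here, no measured compound carries butyl at this place, so these steps guide only the likely size of the change. Both other measured compounds stand higher than compound 3, so a modest move towards a higher number is expected rather than a further fall. The expected step runs a 2.3-fold higher number from compound 3 to compound 4 (0.36 log units; beyond the scatter). For compound 4 the estimate is 20000 nM, with an expected range of 7000 nM to 45000 nM.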

Compound 4, half-maximal inhibitory concentration: 12000 nM
Compound 4: middle estimate off by 1.7-fold (0.22 log units), on the high side; low and high end bracket the measured number.
By their numbers in this assay, from the lowest: compounds 3 and 4 (each within the scatter of the next); then compounds 2 and 1 (each within the scatter of the next).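

In this assay, the step of a 1.4-fold higher number from compound 3 to compound 4 (0.14 log units; within the scatter) shows that at this place, four bonds along the chain from an aromatic carbon, butyl and sec-butyl cannot be told apart, so the branch of compound 3 is not needed for its number. The unbranched chain also separates compound 4 from the two other branched chains: pentyl in place of 1-methylbutyl gives a 2.4-fold lower number from compound 2 to compound 4 (0.38 log units; beyond the scatter) and is beyond the scatter, and propyl in place of isopropyl gives a 2.8-fold lower number from compound 1 to compound 4 (0.45 log units; beyond the scatter) and is also beyond the scatter, both steps modest. Branching as such therefore does not set the number in these four compounds, since compounds 1 and 2 stand higher than compound 4 while compound 3, also branched, stands within the scatter of it.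

No measurement at hand gives a reason for these differences. The compounds shown leave open whether a longer chain, or an amine at the end of the chain, would keep the numbers of compounds 3 and 4 or move them away from this range.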